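The source may report more compounds than this note shows. Statements on the series, on what has been measured and on what is new or still open speak of the compounds shown alone.

Two compounds built on a shared core have so far been characterised in an ADME assay on a cell-free system (plasma, Homo sapiens) for metabolic stability, read by LC-MS; on this read-out higher numbers stand for a longer-lived compound and lower numbers for a shorter-lived compound. Compound 1 `NCc1ccc(C(=O)Nc2ccncc2F)cc1-c1cccc(C(=O)Oc2ccccc2)c1` gives 0.117 h in this assay. Within the data shown here, compound 2 `CCCCCCOC(=O)c1cccc(-c2cc(C(=O)Nc3ccncc3)ccc2CN)c1` gives 0.833 h, the higher of the two numbers; its only neighbour is compound 1, whose number sits well below it, a gap that lies beyond the usual scatter of this assay.

The next compound, compound 3 `COC(=O)c1cccc(-c2cc(C(=O)Nc3ccncc3)ccc2CN)c1`, has not yet been measured. It differs from compound 2 in a single place: hydrogen in place of pentyl on a saturated chain carbon bound to an oxygen next to a carbonyl group. Among the measured compounds shown here, no pair of measured compounds traces this particular change, so any expectation rests on the two values above and on the change itself. In this assay the expected step is a 2.1-fold lower number from compound 2 to compound 3 (0.32 log units; beyond the scatter), a move downward that would be somewhat larger than the scatter. Compound 3 is therefore estimated at 0.4 h in this assay, within a range from 0.15 h to 1.1 h.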

Compound 3, half-life: 1.52 h
Beside the measured number, compound 3's estimate is 3.8-fold (0.58 log units) below it, and the stated range ends below it.
By their numbers in this assay, from the lowest: compound 1; then compounds 2 and 3 (each within the scatter of the next).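

In this assay, hydrogen in place of pentyl on a saturated chain carbon bound to an oxygen next to a carbonyl group gives a 1.8-fold higher number from compound 2 to compound 3 (0.26 log units; within the scatter) and this is the first step shown at this position. Hexyloxycarbonyl and methoxycarbonyl therefore cannot be told apart on this read-out, so removing the pentyl leaves no change here that exceeds the difference expected between repeated measurements. Nothing among the available data explains this result.

The compounds shown span only the hexyl and methyl esters, so it remains open whether a chain of intermediate length, such as butyl, or a branched one, such as tert-butyl, would fall in the same range. On these data alone, it also remains open how a carboxylic acid or a primary amide would read at this position in place of the ester.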